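This account rests on a few compounds, and the source may have more. Where it says the series, first, only, none or still open, it means among the compounds named here.

Measured in a functional assay on A549 cells (Homo sapiens) for antiproliferative activity, read by MTT assay, with a stated time of 48 h; on this read-out higher numbers stand for weaker inhibition and lower numbers for stronger inhibition:
- Compound 1 `COc1ccc2c(/C=C/C(=O)c3cc(N)c(OC)c(OC)c3)c[nH]c2c1`: 193 nM
- Compound 2 `COc1ccc2c(/C=C/C(=O)c3cc(OC)c(OC)c([N+](=O)[O-])c3)c[nH]c2c1`: 331 nM

Within the data shown here, only one measured step exists in this small set: a 1.7-fold higher number from compound 1 to compound 2 (0.23 log units; within the scatter). Among the measured compounds shown here, compound 2 therefore stands level with its sole measured neighbour in this assay, and neither compound can be separated from the other on these numbers.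

Compound 3 `COc1ccc2c(/C=C/C(=O)c3cc(OC)c(OC)c([N+](=O)[O-])c3)cn(C)c2c1` keeps the structure of compound 2 except at one place: methyl in place of hydrogen on an aromatic nitrogen. This is methyl in place of hydrogen on an aromatic nitrogen. The measured step offers little guidance, since it exchanges nitro for amino on an aromatic carbon and leaves this nitrogen untouched. For the measured compounds named here, no measured pair changes the nitrogen, so the data give no direction for the new step. The only size on record is the small one above, and no step beyond the scatter is expected in this assay, though the range must stay wide without a direct precedent.

For compound 3 the expected value is 300 nM, with an estimated range of 100 nM to 900 nM. This estimate means an expected 1.1-fold lower number from compound 2 to compound 3 (0.04 log units; within the scatter).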

Compound 3, half-maximal inhibitory concentration: 1020 nM
For compound 3 the middle estimate is 3.4-fold (0.53 log units) below the measured one; the whole stated range lies below it.
By their numbers in this assay, from the lowest: compounds 1 and 2 (each within the scatter of the next); then compound 3.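

In this assay, among these compounds, methyl in place of hydrogen on an aromatic nitrogen gives a 3.1-fold higher number from compound 2 to compound 3 (0.49 log units; beyond the scatter), and this is the only step in the set that lies beyond the scatter, whereas nitro in place of amino, a 1.7-fold higher number from compound 1 to compound 2 (0.23 log units; within the scatter), stays within it. The nitrogen of the five-membered aromatic ring is therefore a place where the read-out does respond: with the nitro group present, adding a single carbon there gives modestly weaker inhibition, and compound 2, which keeps the hydrogen, is the better of the pair. No measurement bearing on the origin of this loss is available, so the result records its size and direction and nothing about its cause.

The compounds shown leave open whether the step is tied to the nitro group or would appear at a similar size if the same methyl were placed on the nitrogen of compound 1, which carries the amino group. They also leave open how the number would respond to other groups on this nitrogen, such as an ethyl group, a benzyl group or a longer chain ending in an amine.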